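The compounds below may be only part of what the source reports. "The series", "measured", "known", "first", "only" and "open" are said of these compounds alone.

Compounds measured so far:

Compound 1, `O=C(O)c1ccc(-c2nn(Cc3ccccc3)c3ccccc23)cc1`: in a functional assay on cells (Platelet, Homo sapiens) for inhibition (on this read-out higher numbers stand for weaker inhibition and lower numbers for stronger inhibition), compound 1 gives > 10000 nM, which is a limit of the assay and not a number.

Compound 2, `CCNC(=O)c1ccc(-c2nn(Cc3ccccc3)c3ccccc23)cc1`: in this assay compound 2 gives > 10000 nM, again a limit of the assay rather than a number.

The two compounds share a core and differ only at the carbonyl carbon, where compound 2 carries ethylamino in place of hydroxy. For the measured compounds named here, the step from compound 1 to compound 2 is a step that the two limits leave unreadable from compound 1 to compound 2, so its size cannot be read; both values sit at the limit of > 10000 nM in this assay, at which 2 of the 2 values shown sit, and this is all that the numbers so far show about where compound 2 stands.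

Compound 3, `CCOC(=O)/C=C/c1ccc(-c2nn(Cc3ccccc3)c3ccccc23)cc1`, has not yet been measured. It differs from compound 2 in one place: 2-(ethoxycarbonyl)ethenyl in place of ethylcarbamoyl on an aromatic carbon. The change lengthens the chain and removes the amide hydrogen, while the core is untouched. Going by the values given here, no measured step bears directly on this change, and the one step recorded is unreadable, so there is no measured guide to the size or direction of the step in this assay. Compound 3 is therefore expected to stay near the limit, with a step that the limit leaves unreadable from compound 2 to compound 3 as the estimated step. The estimate for compound 3 in this assay is 15000 nM, within a range from 3000 nM to 60000 nM.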

Compound 3, half-maximal inhibitory concentration: > 10000 nM
Compound 3 ended at the assay's limit; the forecaster's own chance of this, stated with the estimate: 70%; the middle value is on the limit's open side.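

For the compounds shown here, compound 3 also gives a limit of the assay and not a number, so no step among compound 1, compound 2 and compound 3 can be read: the limit of > 10000 nM in this assay, at which 3 of the 3 values shown sit.

The compounds shown leave open how much these three differ in this assay and whether any group at this place on the shared core gives a measurable inhibition.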